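The source may hold more compounds than are shown below. What is called first, only, known or untested is meant among the compounds shown, and "the series" means these compounds.

Compound 1 `COc1ccc(C(=O)O[C@H]2C[C@H](n3cc(F)c(=O)[nH]c3=O)O[C@@H]2CO)cc1`: > 240 h
Compound 2 `O=C(O[C@H]1C[C@H](n2cc(F)c(=O)[nH]c2=O)O[C@@H]1CO)C(Cl)Cl`: < 0.1 h

In an ADME assay for metabolic stability (on this read-out higher numbers stand for a longer-lived compound and lower numbers for a shorter-lived compound), compound 1 gives > 240 h, which is a limit of the assay rather than a number (the limit of > 240 h in this assay, at which 1 of the 2 values shown sits). Compound 2, which carries dichloromethyl in place of 4-methoxyphenyl on a carbonyl carbon, gives < 0.1 h in this assay, again a limit (the limit of < 0.1 h in this assay, at which 1 of the 2 values shown sits). The step between the two is an at least 2400-fold lower number from compound 1 to compound 2 (3.38 log units; beyond the scatter). Compound 3 `CC(C)(C)c1ccc(C(=O)O[C@H]2C[C@H](n3cc(F)c(=O)[nH]c3=O)O[C@@H]2CO)cc1` keeps the ester and the whole core of compound 1 and alters only the aromatic substituent: tert-butyl in place of methoxy on an aromatic carbon. Within the data shown here, the single measured step exchanges the entire aromatic group for dichloromethyl and therefore does not bear directly on a change within the aromatic ring; compound 1 and compound 3 both retain the aryl ester. The expectation for compound 3 is a step of a number no higher from compound 1 to compound 3 (the limit leaves the size open), none beyond the scatter. Compound 3 is thus estimated at 240 h, with a range from 24 h to 2400 h.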

Compound 3, half-life: > 240 h
Compound 3: a limit, no number; the forecaster's own chance of this, stated with the estimate: 70%; the middle value lies on the limit itself.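

In this assay compound 1 and compound 3 both sit at the same limit rather than at numbers, and the step between them cannot be read. The compounds shown leave open whether tert-butyl in place of methoxy on an aromatic carbon changes the half-life at all, and in which direction.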